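This account rests on a few compounds, and the source may have more. Where it says the series, first, only, none or still open, it means among the compounds named here.

Measured in an ADME assay on a cell-free system (plasma, Homo sapiens) for metabolic stability, read by HPLC; a higher number here means that the compound lasts longer, a lower number that the compound disappears faster:
compound 1 `CC(=O)c1ccc(/N=N/N(C)C(=O)NCCSc2ccc(O)cc2)cc1` gives 61.6 h;
compound 2 `CN(/N=N/c1ccc(Br)cc1)C(=O)CCc1ccc(O)cc1` gives 8.3 h;
compound 3 `CCOC(=O)c1ccc(/N=N/N(C)C(=O)NCCSc2ccc(O)cc2)cc1` gives 30.5 h.

Among these three numbers compound 2 stands lowest; its nearest neighbour is compound 3, and compound 1 lies furthest from it, both separated from it by more than the scatter. Compound 4 `CCOC(=O)c1ccc(/N=N/N(C)C(=O)CCc2ccc(O)cc2)cc1` has not yet been measured in this assay. It differs from compound 2 in one place: ethoxycarbonyl in place of bromo on an aromatic carbon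

For the measured compounds named here, no measured step covers this change. Going by the values given here, the only step recorded, a 2.0-fold lower number from compound 1 to compound 3 (0.31 log units; beyond the scatter), concerns the carbonyl substituent and not the exchange of a bromo for an ethoxycarbonyl group, so it bears on the question at most indirectly, by showing that the ethyl ester version of that pair stands somewhat lower than the methyl ketone. Compound 3 and compound 2 share the ethoxycarbonyl-bearing and bromo-bearing rings in question but also differ in the chain, so their two values alone cannot be read as the effect of the exchange. The account therefore expects a step of a 1.4-fold higher number from compound 2 to compound 4 (0.16 log units; within the scatter) of small size, in no firmly predictable direction, with a wide range. For compound 4 the account estimates 12 h in this assay, between 5 h and 30 h.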

Compound 4, half-life: 6.57 h
Estimate against measurement, compound 4: 1.8-fold (0.26 log units) above; the measured number falls inside the stated range.
By their numbers in this assay, from the lowest: compounds 4 and 2 (each within the scatter of the next); then compound 3; then compound 1.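

The exchange of bromo for ethoxycarbonyl, on an aromatic carbon para to a large group, gives in this assay a 1.3-fold lower number from compound 2 to compound 4 (0.10 log units; within the scatter) and so leaves compound 2 and compound 4 indistinguishable. For the compounds shown here, this is the first direct reading at this position with the propanoyl-type chain of compound 2 kept fixed: replacing 1 heavy atom with 5 heavy atoms, including 2 hydrogen-bond acceptors, does not produce a difference that can be told from the scatter. Going by these compounds alone, the only earlier step at this ring substituent, a 2.0-fold lower number from compound 1 to compound 3 (0.31 log units; beyond the scatter) and beyond the scatter, belongs to another chain and to another exchange, so it does not carry over to this one. No measurement here explains why this exchange leaves the half-life within the scatter.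

The compounds shown leave open whether bromo in place of ethoxycarbonyl would give a similarly small step on the chain of compound 1 and compound 3, which carries the sulfur atom. They also leave open how a carboxylic acid or an amine at this position would stand in this assay when set against bromo and ethoxycarbonyl.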